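Methoxy added to a weakly cytotoxic indole core

The source may report more compounds than this note shows. Statements on the series, on what has been measured and on what is new or still open speak of the compounds shown alone.

Measured compounds:
Compound 1 `c1ccc2[nH]c(-n3cccn3)cc2c1` — > 100000 nM
Compound 2 `O=C1NC(=O)c2c1c1c3cc(O)ccc3[nH]c1c1cccn21` — > 100000 nM
Compound 3 `COc1ccc2[nH]c3c4cn[nH]c4c4c(c3c2c1)C(=O)NC4=O` — 45000 nM

In a functional assay on Hs 683 cells (Homo sapiens) for cytotoxicity, read by MTT assay, with a stated time of 72 h (on this read-out higher numbers stand for weaker inhibition and lower numbers for stronger inhibition), compound 1 gives only > 100000 nM, which is a limit of the assay rather than a number. Compound 2 also stops at a limit, > 100000 nM. For the measured compounds named here, compound 3 is the one compound with a measured value, 45000 nM. Going by the values given here, compound 1 therefore stands at the limit of > 100000 nM in this assay, at which 2 of the 3 values shown sit, and no measured step connects it to either of the others, since all three differ in more than one place.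

Compound 4 `COc1ccc2[nH]c(-n3cccn3)cc2c1` differs from compound 1 in a single way: methoxy in place of hydrogen on an aromatic carbon. Among the compounds with values here, with compound 1 sitting at the limit, no step between measured compounds gives a direction for this change. Compound 4 is therefore expected to show a number no higher from compound 1 to compound 4 (the limit leaves the size open), that is, no movement beyond the scatter, and most likely another limit. The estimate for compound 4 in this assay is 100000 nM, within a range of 30000 nM to 300000 nM.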

Compound 4, half-maximal inhibitory concentration: 69000 nM
Compound 4: the middle estimate sits 1.4-fold (0.16 log units) above what was measured; the measured number falls inside the stated range.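

In this assay, methoxy in place of hydrogen on an aromatic carbon, meta to a fused ring and para to a fused ring, gives an at least 1.4-fold lower number from compound 1 to compound 4 (0.16 log units; that floor lies within the scatter), the first step the series offers at this position. Compound 1 gives > 100000 nM, which is a limit of the assay and not a number. Only the floor of the step can be read, so its true size stays open, and that floor alone does not show a change beyond the scatter: the limit of > 100000 nM in this assay, at which 2 of the 4 values shown sit.

The compounds shown leave open whether an amine or a carboxylic acid at this same position, or a longer chain on the oxygen, would move the number further than methoxy does. For the compounds shown here, they also leave open whether methoxy acts alike on another core, since no single-place step links compound 3, which also carries methoxy, to any other compound.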